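A few compounds are considered here, and "the series" means these few. Any claim that something is new, unique, unknown or untested is made for them only; others in the source may bear on it.

Measured compounds:
- Compound 1 `N#C/C(=C\c1ccc([N+](=O)[O-])cc1)C(=O)O`: in an assay on RBE4 cells for inhibition of Monocarboxylate transporter 1 (Rattus norvegicus), with a stated time of 15 min (a higher number here means a weaker inhibitor, a lower number a stronger inhibitor), compound 1 gives 500 nM.
- Compound 2 `CCCN(CCC)c1ccc(/C=C(\C#N)C(=O)O)cc1`: in this assay compound 2 gives 10 nM.
- Compound 3 `C=CCN(CC=C)c1ccc(/C=C(\C#N)C(=O)O)cc1`: in this assay compound 3 gives 110 nM.

Compound 1 stands highest of the three numbers in this assay, so it is the weakest inhibitor of the set. Compound 3 is the nearest to it, yet its number is already beyond the scatter below that of compound 1, and compound 2 lies furthest away, far below compound 1.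

Compound 4 `N#C/C(=C\c1ccc(N2CCCC2)cc1)C(=O)O` has not been measured. It differs from compound 1 in one place: pyrrolidin-1-yl in place of nitro on an aromatic carbon. This change takes compound 4 toward compound 2 and compound 3, both of which carry a nitrogen with two carbon substituents at that position and both of which give clearly lower numbers in this assay than compound 1. For the measured compounds named here, no measured pair shows this exact step, so the size must be estimated. Compound 4 is expected to come out near the lower end of the measured range, because compound 2 gives 10 nM in this assay. For compound 4 the estimate is 20 nM, with a range from 5 nM to 80 nM, which would be a large drop a 25-fold lower number from compound 1 to compound 4 (1.40 log units; beyond the scatter), well beyond the scatter.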

Compound 4, half-maximal inhibitory concentration: 70 nM
The estimate for compound 4 lay 3.5-fold (0.54 log units) below the measured number, within the range that was stated.
By their numbers in this assay, from the lowest: compound 2; then compounds 4 and 3 (each within the scatter of the next); then compound 1.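

In this assay, for the compounds shown here, pyrrolidin-1-yl in place of nitro on the aromatic carbon gives a 7.1-fold lower number from compound 1 to compound 4 (0.85 log units; beyond the scatter), the first direct step at this position, and it shows that a nitrogen tied back into a five-membered ring also gives a lower number than nitro. Compound 4 at 70 nM sits within the scatter of compound 3 at 110 nM, so the ring and the two allyl chains cannot be told apart here, while compound 2 gives 10 nM with its two propyl chains. Nothing measured here bears on why the number falls with this change.

The compounds shown leave open how a piperidin-1-yl or morpholin-4-yl ring, or shorter or longer chains on that nitrogen, would read at this position. They also leave open whether an unsubstituted amine would give a lower number than nitro.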